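A few compounds are considered here, and "the series" means these few. Any claim that something is new, unique, unknown or untested is made for them only; others in the source may bear on it.

Compounds measured in a functional assay on DU-145 cells (Homo sapiens) for antiproliferative activity, read by WST assay, with a stated time of 48 h, tested at 1 uM; a higher number here means a stronger effect of the compound at the concentration tested, a lower number a weaker effect:
compound 1 `Cc1[nH]n(-c2nc3cc(Cl)ccc3[nH]2)c(=O)c1Cc1ccccc1`, 86%;
compound 2 `Cc1ccc2[nH]c(-n3[nH]c(C)c(Cc4ccccc4)c3=O)nc2c1`, 35%;
compound 3 `Cc1ccc2[nH]c(-n3[nH]c(C)c(Cc4ccc(Cl)cc4)c3=O)nc2c1`, -1%.

Compound 2 stands second highest of the three numbers, with a number 51 percentage points lower from compound 1 to compound 2 (beyond the scatter) above it and a number 36 percentage points lower from compound 2 to compound 3 (beyond the scatter) below it, both beyond the scatter.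

Compound 4 `Cc1[nH]n(-c2nc3cc(-c4ccc(Cl)cc4)ccc3[nH]2)c(=O)c1Cc1ccccc1` differs from compound 2 in one place: 4-chlorophenyl in place of methyl on an aromatic carbon. Within the data shown here, no measured step makes this same change. The step that bears most on it is a number 51 percentage points lower from compound 1 to compound 2 (beyond the scatter), a large fall at the same place when methyl replaced chloro, while a number 36 percentage points lower from compound 2 to compound 3 (beyond the scatter) shows a chloro entering elsewhere lowering the number further. An upward step of a number 15 percentage points higher from compound 2 to compound 4 (beyond the scatter) is therefore expected, with wide uncertainty. Compound 4 is estimated to give 50%, within 10% to 85%.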

Compound 4, a percentage reported as inhibition, at one concentration (the size of the read-out at that concentration, not a potency): 70%
The estimate for compound 4 lay 20 percentage points below the measured number; the measured number falls inside the stated range.
By their numbers in this assay, from the lowest: compound 3; then compound 2; then compound 4; then compound 1.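

In this assay, among these compounds, this aromatic carbon, so far seen only with chloro and methyl, also carries the much larger 4-chlorophenyl, with a number 35 percentage points higher from compound 2 to compound 4 (beyond the scatter) and with a number 16 percentage points lower from compound 1 to compound 4 (beyond the scatter) as the comparison with chloro. Both chloro and 4-chlorophenyl therefore stand above methyl at this place, though the added aromatic ring does not reach the number seen with chloro. Nothing measured here gives a reason for this order. From the compounds shown here alone, it remains open whether an unsubstituted phenyl, an amine or a carboxylic acid at this place would keep the number up.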